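A few compounds are considered here, and "the series" means these few. Any claim that something is new, unique, unknown or untested is made for them only; others in the source may bear on it.

Values measured so far in a functional assay on SW620/5-FU cells (Homo sapiens) for cytotoxicity, read by MTT assay, with a stated time of 48 h, in the presence of a further agent that is not named here (a higher number here means that more compound is needed for the effect, a lower number that less compound is needed), are these:

- compound 1 `COc1ccc(-c2cc(NNC(=O)Nc3cc(Cl)nc(Cl)c3)nc3c2cnn3C)cc1` gives 18500 nM
- compound 2 `Cn1ncc2c(-c3ccc(F)cc3)cc(NNC(=O)Nc3cc(Cl)cc(Cl)c3)nc21` gives 54300 nM
- compound 3 `CC(C)c1cc(NNC(=O)Nc2cc(Cl)nc(Cl)c2)nc2c1cnn2C` gives 50100 nM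

Compound 3 at 50100 nM lies within the scatter of compound 2 at 54300 nM and cannot be separated from it. It stands clearly apart from compound 1, as a 2.7-fold higher number from compound 1 to compound 3 (0.43 log units; beyond the scatter) shows.

Next is compound 4 `Cn1ncc2c(-c3ccc(F)cc3)cc(NNC(=O)Nc3cc(Cl)nc(Cl)c3)nc21` with 4-fluorophenyl in place of isopropyl on an aromatic carbon, opposite the ring nitrogen. The change is 4-fluorophenyl in place of isopropyl on an aromatic carbon and nothing else differs between the two.

For the measured compounds named here, one measured step touches the same place. That step, a 2.7-fold higher number from compound 1 to compound 3 (0.43 log units; beyond the scatter) is modest and involves 4-methoxyphenyl rather than 4-fluorophenyl. Read in reverse, it points to a lower number in this assay when the aromatic group replaces isopropyl. Caution comes from compound 2, which also carries 4-fluorophenyl yet gives 54300 nM and differs from compound 4 elsewhere in the molecule. A modest move to a lower number is therefore expected, no larger than the measured step, and the expected change is a 2.1-fold lower number from compound 3 to compound 4 (0.32 log units; beyond the scatter) in size.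

Compound 4 is estimated at 24000 nM with an expected range from 10000 nM to 55000 nM in this read-out.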

Compound 4, half-maximal effective concentration: 9150 nM
Beside the measured number, compound 4's estimate is 2.6-fold (0.42 log units) above it, and the stated range ends above it.
By their numbers in this assay, from the lowest: compound 4; then compound 1; then compounds 3 and 2 (each within the scatter of the next).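

Opposite the ring nitrogen, 4-fluorophenyl in place of isopropyl gives a 5.5-fold lower number from compound 3 to compound 4 (0.74 log units; beyond the scatter) in this assay, so with a 2.7-fold higher number from compound 1 to compound 3 (0.43 log units; beyond the scatter) read in reverse, both aromatic groups shown at this position go with a lower number than isopropyl. The group on that aromatic ring also counts, since fluoro in place of methoxy gives a 2.0-fold lower number from compound 1 to compound 4 (0.31 log units; beyond the scatter) and separates two compounds that the earlier data could compare only through isopropyl. The gain from 4-fluorophenyl also depends on the other end of the molecule: 2,6-dichloropyridin-4-yl in place of 3,5-dichlorophenyl gives a 5.9-fold lower number from compound 2 to compound 4 (0.77 log units; beyond the scatter), so the low number of compound 4 belongs to this pairing and not to 4-fluorophenyl alone.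

Nothing at hand explains any of these steps. From the compounds shown here alone, it remains open whether an amine or a carboxylic acid on the aromatic ring, or a longer chain in place of isopropyl, would hold or lower the number in this assay, and whether 4-methoxyphenyl would also respond to the change to 3,5-dichlorophenyl.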